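A few compounds are considered here, and "the series" means these few. Any claim that something is new, unique, unknown or untested is made for them only; others in the source may bear on it.

Of the compounds shown here, three sharing one core have been measured in an assay on CHO cells for displacement of a labelled ligand from adenosine receptor A1 (Homo sapiens), read by scintillation counting, with a stated time of 90 min, in the presence of a further agent that is not named here; a higher number here means a weaker inhibitor, a lower number a stronger inhibitor. Compound 1 `CCCn1c(=O)[nH]c2nc(-c3ccc(S(=O)(=O)N4CCN(c5ccc(Br)cc5)CC4)cc3)[nH]c2c1=O` carries a 4-bromophenyl on an amine nitrogen in a ring; in this assay compound 1 gives > 1000 nM, which is a limit of the assay and not a number. Compound 3 `CCCn1c(=O)[nH]c2nc(-c3ccc(S(=O)(=O)N4CCN(c5cccc(Br)c5)CC4)cc3)[nH]c2c1=O`, with a 3-bromophenyl in that place, gives > 1000 nM, again only a limit. Compound 2 `CCCn1c(=O)[nH]c2nc(-c3ccc(S(=O)(=O)N4CCN(C)CC4)cc3)[nH]c2c1=O`, bearing a methyl there, gives 334 nM. Compound 3 therefore sits at the limit, and so does one further value; the limit of > 1000 nM in this assay, at which 2 of the 3 values shown sit, is where two of the three numbers stand. The step of an at least 2.9-fold higher number from compound 2 to compound 3 (0.47 log units; beyond the scatter) is at least modest, and an at least 2.9-fold lower number from compound 1 to compound 2 (0.47 log units; beyond the scatter) points the same way, while a step that the two limits leave unreadable from compound 1 to compound 3 cannot be read between two limits. Compound 4 `CCCn1c(=O)[nH]c2nc(-c3ccc(S(=O)(=O)N4CCN(C(C)c5ccccc5)CC4)cc3)[nH]c2c1=O` arises through (1-phenylethyl in place of 3-bromophenyl on an amine nitrogen in a ring). The change moves away from the bromophenyl groups of compounds 1 and 3, though not to the methyl of compound 2, so compound 4 is expected to return from the limit toward a readable number. The expected step is an at least 1.2-fold lower number from compound 3 to compound 4 (0.09 log units; that floor lies within the scatter). Compound 4 is estimated at 800 nM, between 200 nM and 3000 nM.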

Compound 4, inhibition constant: >= 1000 nM
Compound 4: no number, only a limit; the forecaster's own chance of this, stated with the estimate: 40%; middle value at least 1.2-fold (0.09 log units) from the limit.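

In this assay compound 4 gives >= 1000 nM, which is a limit of the assay and not a number. At this amine nitrogen in a ring, then, a 1-phenylethyl carrying no bromine also fails to give a readable number, so among the compounds shown only the methyl of compound 2 does, and the one readable new step is an at least 2.9-fold higher number from compound 2 to compound 4 (0.47 log units; beyond the scatter). The steps linking compound 4 to compound 1 and compound 3 cannot be read, so the 1-phenylethyl and the two bromophenyl groups cannot be ranked against one another.

From the compounds shown here alone, how far the true values of compound 1, compound 3 and compound 4 lie from the limit stays open. So does the question of whether an ethyl or a benzyl on that nitrogen would give a readable number, and where it would fall relative to compound 2.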